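The compounds below may be only part of what the source reports. "The series", "measured", "known", "first", "only" and "open" are said of these compounds alone.

Of the compounds shown here, three sharing one core have been measured in an assay on cells for agonist activity at vitamin D3 receptor (Homo sapiens), with a stated time of 96 h; on this read-out higher numbers stand for an effect only at larger amounts of compound and lower numbers for an effect already at smaller amounts. Compound 1 `CCn1c(C(=O)N(CCC#N)CCC#N)ccc1C(CC)(CC)c1ccc(OCCC(O)(CC)CC)c(C)c1` sits at a limit of the assay and gives > 10000 nM. Compound 2 `C#CC(C)OC(=O)c1ccc(C(CC)(CC)c2ccc(OCCC(O)(CC)CC)c(C)c2)n1CC` gives 2650 nM. Compound 3 `CCC(C)C(NC(=O)c1ccc(C(CC)(CC)c2ccc(OCCC(O)(CC)CC)c(C)c2)n1CC)C(=O)OC` likewise sits at a limit of the assay and gives > 10000 nM. Compound 3 therefore stands where compound 1 stands, with no number of its own, and the pair is joined by a step that the two limits leave unreadable from compound 1 to compound 3. The readable steps are an at least 3.7-fold lower number from compound 1 to compound 2 (0.57 log units; beyond the scatter) and an at least 3.7-fold higher number from compound 2 to compound 3 (0.57 log units; beyond the scatter), with the limit of > 10000 nM in this assay, at which 2 of the 3 values shown sit, setting the edge for two of the three.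

Compound 4 `CCOC(=O)CN(C)C(=O)c1ccc(C(CC)(CC)c2ccc(OCCC(O)(CC)CC)c(C)c2)n1CC` is not yet measured. It differs from compound 3 by a group of 8 heavy atoms (5 carbon, 1 nitrogen, 2 oxygen; no ring) in place of a group of 10 heavy atoms (7 carbon, 1 nitrogen, 2 oxygen; no ring), on a carbonyl carbon. Within the data shown here, the steps that bear on it are those exchanging the group on that carbonyl carbon, an at least 3.7-fold higher number from compound 2 to compound 3 (0.57 log units; beyond the scatter) and an at least 3.7-fold lower number from compound 1 to compound 2 (0.57 log units; beyond the scatter). In both, the compounds carrying a nitrogen on the carbonyl carbon, compound 1 and compound 3, rest at the limit, and only compound 2 gives a number. Compound 4 keeps a nitrogen on that carbonyl carbon, so compound 4 is expected to remain at or close to the limit, an expected step of a number no higher from compound 3 to compound 4 (the limit leaves the size open) of no readable size. The estimate for compound 4 in this assay is 10000 nM, within 3000 nM to 30000 nM.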

Compound 4, half-maximal effective concentration: 520 nM
The estimate for compound 4 lay 19-fold (1.28 log units) above the measured number, and the stated range ends above it.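

In this assay, a nitrogen on the carbonyl carbon does not in itself hold a compound at the edge of the read-out: ((ethoxycarbonyl)methyl)(methyl)amino brings an at least 19-fold lower number from compound 3 to compound 4 (1.28 log units; beyond the scatter) and an at least 19-fold lower number from compound 1 to compound 4 (1.28 log units; beyond the scatter). The nitrogen-bearing group also passes the only oxygen-linked group shown, with a 5.1-fold lower number from compound 2 to compound 4 (0.71 log units; beyond the scatter), which gives compound 4 the lowest number of the four compounds. Compound 1 and compound 3 each rest on a limit and not on a number, so the two larger steps give only a smallest size: the limit of > 10000 nM in this assay, at which 2 of the 4 values shown sit.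

The compounds shown do not separate the part played by the methyl on the nitrogen from that of the ethyl ester, and compound 3 also ends in an ester yet stays at the limit. A carboxylic acid in place of the ethyl ester, a hydrogen in place of the methyl on the nitrogen, or a longer chain between the nitrogen and the ester would each test one of these parts on its own.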